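The compounds below may be only part of what the source reports. "The series", "measured", "known", "first", "only" and "open" are said of these compounds alone.

Measured so far:
compound 1 `CC[C@@H](C)[C@H](NC(=O)c1ccc(C(CC)(CC)c2ccc(OCC(=O)C(C)(C)C)c(C)c2)n1CC)C(=O)OC`: 590 nM
compound 2 `CC[C@@H](C)[C@H](NC(=O)c1ccc(C(CC)(CC)c2ccc(OCC(O)C(C)(C)C)c(C)c2)n1CC)C(=O)OC`: 26 nM

In an assay on HL-60 cells for agonist activity at vitamin D3 receptor (Homo sapiens), read by microscopy, with a stated time of 96 h (on this read-out lower numbers stand for an effect already at smaller amounts and higher numbers for an effect only at larger amounts of compound), compound 2 gives the lower of the two numbers; the step of a 23-fold lower number from compound 1 to compound 2 (1.36 log units; beyond the scatter) separates it from compound 1. Compound 3 `CCn1c(C(=O)NCC(OC)OC)ccc1C(CC)(CC)c1ccc(OCC(O)C(C)(C)C)c(C)c1` differs from compound 2 by 2,2-dimethoxyethyl in place of 1-(methoxycarbonyl)-2-methylbutyl on an amide-type nitrogen. Among the measured compounds shown here, no measured step touches this part of the molecule; the only step on record concerns the chain bound to the aromatic oxygen, so it does not bear on this change. Because compound 2 gives 26 nM and its hydroxy chain is kept, the number for compound 3 is estimated near that of compound 2, with wide uncertainty: a 3.1-fold higher number from compound 2 to compound 3 (0.49 log units; beyond the scatter) is expected, giving an estimate of 80 nM in the range 15 nM to 400 nM.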

Compound 3, half-maximal effective concentration: 150 nM
For compound 3 the middle estimate is 1.9-fold (0.27 log units) below the measured one; measured number inside the range.
By their numbers in this assay, from the lowest: compound 2; then compound 3; then compound 1.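

The substituent on the amide-type nitrogen is shown here to affect the number in this assay: 2,2-dimethoxyethyl in place of 1-(methoxycarbonyl)-2-methylbutyl gives a 5.8-fold higher number from compound 2 to compound 3 (0.76 log units; beyond the scatter), a modest step. The position therefore carries a measurable but smaller effect than the change on the chain at the aromatic oxygen. No available evidence explains this shift.

The pair cannot separate the contributions of the ester, the branched chain and the two stereocentres, which all leave together. On these data alone, a carboxylic acid in place of the methyl ester remains open, as does a longer chain on that nitrogen.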